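Phenyl to 4-methylphenyl: from compound 3 to compound 4

The compounds below may be only part of what the source reports. "The series", "measured", "known", "first", "only" and "open" are said of these compounds alone.

Of the compounds shown here, three sharing one core have been read in a functional assay on U-251 cells (Homo sapiens) for inhibition, read by sulforhodamine B assay, with a stated time of 48 h; a higher number here means a weaker inhibitor of growth, a lower number a stronger inhibitor of growth. Compound 1 `CC(C)(C)NCc1c(C(=O)O)nn(-c2ccc(Cl)cc2)c1-c1ccc(F)cc1` gives only a limit, > 623000 nM. Compound 2 `CC(C)(C)NCc1c(C(=O)O)nn(-c2ccc(Cl)cc2)c1-c1ccc(Cl)cc1`, with chloro in place of that fluoro, gives a number, 518000 nM. Compound 3 `CC(C)(C)NCc1c(C(=O)O)nn(-c2ccc(Cl)cc2)c1-c1ccccc1`, with hydrogen on that aromatic carbon, likewise gives only a limit, > 652000 nM. Compound 3 thus has no number of its own, and one further compound in the set also stands at a limit.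

Compound 4 `Cc1ccc(-c2c(CNC(C)(C)C)c(C(=O)O)nn2-c2ccc(Cl)cc2)cc1` has methyl in place of hydrogen on an aromatic carbon, para to a large group (methyl in place of hydrogen on an aromatic carbon). No methyl has been measured on this carbon, so the guide is the other swaps made there. One is an at least 1.2-fold higher number from compound 2 to compound 3 (0.09 log units; that floor lies within the scatter). The other readable one is an at least 1.2-fold lower number from compound 1 to compound 2 (0.08 log units; that floor lies within the scatter). That leaves a step that the two limits leave unreadable from compound 1 to compound 3. Neither readable step shows a change beyond the scatter, so none is expected here in this assay, in either direction. The estimated step is an at least 1.1-fold lower number from compound 3 to compound 4 (0.05 log units; that floor lies within the scatter). For compound 4 the expected value is 570000 nM. The estimated range for compound 4 runs from 350000 nM to 850000 nM, and a reading reported only as a limit would be no surprise.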

Compound 4, concentration for 50% growth inhibition: > 629000 nM
Compound 4: only a limit was reported; the forecaster's own chance of this, stated with the estimate: 50%; at least 1.1-fold (0.04 log units) between middle value and limit.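

In this assay compound 4, with methyl on this aromatic carbon, gives a limit and not a number: the limit of > 629000 nM in this assay, at which 1 of the 4 values shown sits.

Set against the chloro of compound 2, the only group here to give a number, the swap to methyl reads as an at least 1.2-fold higher number from compound 2 to compound 4 (0.08 log units; that floor lies within the scatter). A carbon group at this place therefore gives no more separation from chloro than the readable steps among the halogen and hydrogen compounds, so across fluoro, chloro, hydrogen and methyl no readable step at this position lies beyond the scatter. Going by these compounds, the steps that link compound 4 to compound 3 and to compound 1 join limit to limit and cannot be read, so the size of the change from hydrogen or fluoro to methyl remains unknown.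

On these data alone, whether any group on this aromatic carbon can bring this assay to a reading clearly removed from these values stays open. An amine or a longer chain such as propyl at this place would put that question to groups unlike the four shown, and an amide in place of the carboxylic acid would test a different part of the shared core.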